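Swapping Phenyl for Pyridin-4-yl in Compound 3

A few compounds are considered here, and "the series" means these few. Any claim that something is new, unique, unknown or untested is made for them only; others in the source may bear on it.

Compound 3 `Cc1ccccc1NC(=O)CN1CCN(c2nnc(Cc3ccccc3)c3ccccc23)CC1` gives 113000 nM in a functional assay on HT-29 cells (Homo sapiens) for cytotoxicity, read by MTT assay, with a stated time of 72 h (on this read-out lower numbers stand for stronger inhibition and higher numbers for weaker inhibition), the highest of the three numbers. Compound 1 `O=C(CN1CCN(c2nnc(Cc3ccncc3)c3ccccc23)CC1)Nc1ccc(Br)cc1` gives 1990 nM and compound 2 `O=C(CN1CCN(c2nnc(Cc3ccncc3)c3ccccc23)CC1)Nc1cccc(Br)c1` gives 1350 nM. Among the compounds with values here, the only measured step, a 1.5-fold lower number from compound 1 to compound 2 (0.17 log units; within the scatter), concerns the bromophenyl on the amide nitrogen and does not touch the change considered here. Compound 4 `Cc1ccccc1NC(=O)CN1CCN(c2nnc(Cc3ccncc3)c3ccccc23)CC1` differs from compound 3 by pyridin-4-yl in place of phenyl on a saturated chain carbon bound to an aromatic carbon. Compounds 1 and 2 carry the same (pyridin-4-yl)methyl as compound 4 but a different aryl on the amide nitrogen, so their wide gap to compound 3 cannot be divided between the two changes. Within the data shown here, no measured step bears directly on this change. Compound 4 is nonetheless expected to lie clearly under compound 3: a 9.4-fold lower number from compound 3 to compound 4 (0.97 log units; beyond the scatter). Compound 4 is estimated at 12000 nM, with a range from 2500 nM to 60000 nM.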

Compound 4, half-maximal inhibitory concentration: 15000 nM
Compound 4: the middle estimate sits 1.3-fold (0.10 log units) below what was measured; the range from low to high includes it.
By their numbers in this assay, from the lowest: compounds 2 and 1 (each within the scatter of the next); then compound 4; then compound 3.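

In this assay the change can now be read on its own: pyridin-4-yl in place of phenyl on a saturated chain carbon bound to an aromatic carbon gives a 7.5-fold lower number from compound 3 to compound 4 (0.88 log units; beyond the scatter) with the amide aryl held fixed. The amide aryl matters as well, with 2-methylphenyl giving an 11-fold higher number from compound 2 to compound 4 (1.05 log units; beyond the scatter) against 3-bromophenyl and a 7.5-fold higher number from compound 1 to compound 4 (0.88 log units; beyond the scatter) against 4-bromophenyl. No evidence at hand accounts for these steps. On these data alone, whether pyridin-3-yl or an amine at this place would behave alike stays open. So does whether the phenyl to pyridin-4-yl step holds with a bromophenyl on the amide nitrogen.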